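The source may hold more compounds than are shown below. What is called first, only, known or untested is meant among the compounds shown, and "the series" means these compounds.

Two compounds have been measured so far in an ADME assay on MDBK cells (Bos taurus) for cytotoxicity; on this read-out higher numbers stand for lower toxicity in this test and lower numbers for higher toxicity in this test:

Compound 1 `CC(C)CCn1ccc2nc(-c3ccccc3)nc-2c1` gives > 100000 nM, a limit of the assay.
Compound 2 `CCC(CC)Cn1ccc2nc(-c3ccccc3)nc-2c1` gives > 100000 nM, also a limit of the assay.

Compound 2 therefore stands at a limit, without a number. For the measured compounds named here, the only measured step, a step that the two limits leave unreadable from compound 1 to compound 2, cannot be sized, and the limit of > 100000 nM in this assay, at which 2 of the 2 values shown sit, covers both compounds. Compound 3 `c1ccc(-c2nc3ccn(CC4CCCCC4)cc-3n2)cc1` carries cyclohexyl in place of pentan-3-yl on a saturated chain carbon bound to an aromatic nitrogen. With no readable step available, no change beyond the scatter is expected in this assay. The expected step is a number no higher from compound 2 to compound 3 (the limit leaves the size open) as estimated here. For compound 3 the estimated value is 100000 nM, with an expected range from 40000 nM to 200000 nM.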

Compound 3, half-maximal cytotoxic concentration: > 100000 nM
Compound 3 was reported as a limit (the forecaster's own chance of this, stated with the estimate: 75%); the middle value lies on the limit itself.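

In this assay compound 3 gives > 100000 nM, a limit of the assay. Its steps from compound 1 and compound 2 therefore cannot be read: the limit of > 100000 nM in this assay, at which 3 of the 3 values shown sit. The compounds shown leave open how far any of them lies from that limit, and whether any group at this place would bring a readable value.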